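Removing a methoxy group from an aryl ester of a dimethylpyrazine acid

The source may report more compounds than this note shows. Statements on the series, on what has been measured and on what is new or still open speak of the compounds shown alone.

The measured compounds and their values:
compound 1, `CCOC(=O)/C=C/c1ccc(OC)c(OC(=O)c2nc(C)c(C)nc2C)c1`, 89%
compound 2, `CCOC(=O)/C=C/c1cc(OC)ccc1OC(=O)c1nc(C)c(C)nc1C`, 27.8%
compound 3, `CCOC(=O)/C=C/c1cccc(OC(=O)c2nc(C)c(C)nc2C)c1`, 39.5%

All three were tested in a functional assay on EA.hy 926 cells (Homo sapiens) for cytotoxicity, read by MTT assay, with stated times of 24 h and 12 h, tested at 50 uM; a higher number here means a stronger effect of the compound at the concentration tested, a lower number a weaker effect. Compound 1 gives 89%. Compound 2 has the same atoms as compound 1, joined differently; the difference between the two cores is not broken down here. In this assay compound 2 gives 27.8%, the lowest of the three numbers.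

Compound 3 differs from compound 1 in one place: hydrogen in place of methoxy on an aromatic carbon. This change brings a number 49.5 percentage points lower from compound 1 to compound 3 (beyond the scatter), a large drop.

Compound 4, `CCOC(=O)/C=C/c1ccccc1OC(=O)c1nc(C)c(C)nc1C`, has not yet been measured. It differs from compound 2 as hydrogen in place of methoxy on an aromatic carbon. Among the measured compounds shown here, the change is the same kind as the one from compound 1 to compound 3, but its surroundings differ: in compound 1 the methoxy sat ortho to a large group and para to the 2-(ethoxycarbonyl)ethenyl group, whereas in compound 2 it sits meta to the 2-(ethoxycarbonyl)ethenyl group and para to a large group.

For the measured compounds named here, for compound 4 a smaller step is expected than the one from compound 1 to compound 3, because compound 2 starts from 27.8% and a percentage cannot fall far below zero. The expected step from compound 2 to compound 4 is a number 9.8 percentage points lower from compound 2 to compound 4 (within the scatter). Compound 4 is therefore estimated at 18%, with a likely range from 2% to 45%.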

Compound 4, a percentage reported as activity, at one concentration (the size of the read-out at that concentration, not a potency): 36.9%
Compound 4: the middle estimate sits 18.9 percentage points below what was measured, within the range that was stated.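

Replacing methoxy with hydrogen does not behave the same way on both cores in this assay. On the core of compound 2, the swap gives a number 9.1 percentage points higher from compound 2 to compound 4 (within the scatter), so this pair shows no change that can be told apart from ordinary variation between repeated measurements. The large drop seen on the core of compound 1 therefore does not carry over to the core of compound 2, which shows that the effect of this swap in this series depends on the surrounding structure, and the two steps really do differ: the same change on two cores in this assay, a number 49.5 percentage points lower (beyond the scatter) from compound 1 to compound 3 and a number 9.1 percentage points higher (within the scatter) from compound 2 to compound 4, 58.6 percentage points apart, beyond the scatter of two such steps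

Among the compounds shown here, this comparison does not show why the two cores respond differently, and with only two pairs, each read at a single concentration, it cannot predict what the swap would do on a further core or say anything about potency.

The compounds shown leave open how other groups would behave in the place of the methoxy, such as an amine, a hydroxyl or a longer ether chain like ethoxy, and whether any of them would depend on the core in the same way. They also leave open what a carboxylic acid or an amide in place of the ethyl ester would do on either core.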